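This account rests on a few compounds, and the source may have more. Where it says the series, first, only, none or still open, it means among the compounds named here.

Measured compounds:
Compound 1 `COc1ccc(N(CC(=O)NCCC[Te]c2ccccc2)C(=O)c2ccccc2)cc1` — 7500 nM
Compound 2 `O=C(COC(=O)C#Cc1ccccc1)NCCC[Te]c1ccccc1` — 7000 nM

In an ADME assay on cells (Fibroblast, Homo sapiens) for cytotoxicity, read by MTT assay, with a stated time of 24 h (on this read-out lower numbers stand for stronger inhibition and higher numbers for weaker inhibition), compound 1 gives 7500 nM. Of the two numbers recorded this is the highest; the nearest is compound 2, which gives 7000 nM, and the gap between the two lies within the scatter, so neither can be said to inhibit more strongly than the other. Compound 3 `COc1ccc(N(CC(=O)NCCC[Se]c2ccccc2)C(=O)c2ccccc2)cc1` has not yet been measured. It differs from compound 1 by a group of 7 heavy atoms (6 carbon, 1 selenium; one six-membered aromatic ring of carbon only) in place of a group of 7 heavy atoms (6 carbon, 1 tellurium; one six-membered aromatic ring of carbon only), on a saturated chain carbon, three bonds along the chain from an amide-type nitrogen. Among the compounds with values here, no pair of measured compounds spans this change, so the data give no direct guide to its size or direction. The step of a 1.6-fold higher number from compound 1 to compound 3 (0.20 log units; within the scatter) is expected to be small, toward a higher number, and not clearly beyond the scatter. Compound 3 is accordingly estimated at 12000 nM in this assay, with a range from 5000 nM to 30000 nM.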

Compound 3, half-maximal inhibitory concentration: >= 100000 nM
Compound 3 was reported as a limit (the forecaster's own chance of this, stated with the estimate: 10%); middle value at least 8.3-fold (0.92 log units) away from the limit.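

In this assay, the group of 7 heavy atoms with 1 selenium in place of the group of 7 heavy atoms with 1 tellurium gives an at least 13-fold higher number from compound 1 to compound 3 (1.12 log units; beyond the scatter). Within the data shown here, the two groups match in heavy-atom count, ring, hydrogen-bond donors, hydrogen-bond acceptors and charge, so this one pair shows that the read-out at this place on the chain can turn on the identity of that single atom, which the earlier compounds, with no step between them, could not show. Compound 3 gives >= 100000 nM, which is a limit of the assay and not a number: the limit of >= 100000 nM in this assay, at which 1 of the 3 values shown sits.

From the compounds shown here alone, whether the same exchange carries over to the core of compound 2 remains open, since this step rests on one pair. Also open, going by these compounds, is what a sulfur atom at this place, or a longer chain carrying the tellurium, would give.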